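The compounds below may be only part of what the source reports. "The series", "measured", "known", "first", "only" and "open" are said of these compounds alone.

Measured compounds:
compound 1 `COC(=O)c1cccc(NC(=O)C2CCCN(C(=O)c3cc(C(F)(F)F)cc(C(F)(F)F)c3)C2)c1` — 0%
compound 2 `O=C(Nc1cccc(Cc2ccccc2)c1)C1CCCN(C(=O)c2cccc(-c3ccco3)c2)C1` — 0%
compound 3 `CCN(CC)S(=O)(=O)c1cccc(C(=O)N2CCCC(C(=O)Nc3ccc(Cl)cc3)C2)c1` — 0%

The three measured compounds share a core and were tested in an ADME assay on PC-3 cells (Homo sapiens) for cytotoxicity, read by WST assay, tested at 100 uM; on this read-out higher numbers stand for more inhibition at the one concentration tested (going by the name of the read-out) and lower numbers for less inhibition. In this assay compound 1 gives 0%, compound 2 gives 0% and compound 3 gives 0%. Compound 1 therefore stands level with compounds 2 and 3 at the digits shown; the gaps to both lie within the scatter, so no order among the three can be read from these numbers.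

Compound 4 `O=C(Nc1cccc(-c2ccco2)c1)C1CCCN(C(=O)c2cc(C(F)(F)F)cc(C(F)(F)F)c2)C1` has not yet been measured in this assay. It differs from compound 1 in one place: furan-2-yl in place of methoxycarbonyl on an aromatic carbon. The group that enters, furan-2-yl, is already present in compound 2, which gives 0% in this assay, and every measured compound sits at the same reading. No step beyond the scatter is expected from compound 1 to compound 4, so the step is estimated at no change at the digits printed from compound 1 to compound 4 (within the scatter). Compound 4 is expected to give 0% in this assay, within a range of 0% to 12%.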

Compound 4, a percentage reported as inhibition, at one concentration (the size of the read-out at that concentration, not a potency): 0%
For compound 4 middle estimate and measured number coincide at the digits printed; low and high end bracket the measured number.
By their numbers in this assay, from the lowest: compounds 1, 2, 3 and 4 (each within the scatter of the next).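

In this assay, putting furan-2-yl in place of methoxycarbonyl on the aromatic carbon gives no change at the digits printed from compound 1 to compound 4 (within the scatter). Among the compounds shown here, this is the first comparison in the set that isolates one place: the earlier compounds differed from one another in more than one place, whereas here a group with no ring gives way to a five-membered aromatic ring and the rest of the molecule stays the same, with no step beyond the scatter. Nothing available explains this result.

On these data alone, whether an amine or a carboxylic acid on this aromatic carbon would shift the reading remains open. The compounds shown also leave open whether any change to the shared core can lift the reading above the one common to all four compounds.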